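The compounds below may be only part of what the source reports. "The series", "measured", "known", "first", "only" and "open" are said of these compounds alone.

Measured in a physicochemical assay, with a stated time of 60 min, tested at 100 ug/mL; on this read-out higher numbers stand for a stronger effect at the one concentration tested and lower numbers for a weaker effect:
compound 1, `CCOC(=O)[C@@H]1CC(=O)c2sccc2[C@H]1c1ccc(OC)cc1`, 34.1%
compound 2, `CCOC(=O)[C@@H]1CC(=O)c2sccc2[C@H]1c1ccc(OCC)cc1`, 38%
compound 3, `CCOC(=O)[C@@H]1CC(=O)c2sccc2[C@H]1c1ccccc1OC`, 31.6%

Compound 3 has the lowest of the three numbers, but its gaps to compound 1 and to compound 2 both lie within the scatter, so the three compounds stand level. Compound 4, `CCOC(=O)[C@@H]1CC(=O)c2sccc2[C@H]1c1ccc(OC)cc1OC`, differs from compound 3 by methoxy in place of hydrogen on an aromatic carbon. Among the measured compounds shown here, the only measured step, a number 3.9 percentage points higher from compound 1 to compound 2 (within the scatter), concerns a saturated chain carbon rather than the aromatic ring and stayed within the scatter; no measured step adds a second methoxy group to the ring, so its bearing on the present change is indirect. No change beyond the scatter is therefore expected in this assay for compound 4; the expected step is a number 0.4 percentage points higher from compound 3 to compound 4 (within the scatter). Compound 4 is estimated at 32%, with a range of 20% to 45%.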

Compound 4, a percentage reported as activity, at one concentration (the size of the read-out at that concentration, not a potency): 26.8%
Estimate against measurement, compound 4: 5.2 percentage points above; the range from low to high includes it.
By their numbers in this assay, from the lowest: compounds 4, 3, 1 and 2 (each within the scatter of the next, the first and the last beyond it).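

Methoxy in place of hydrogen on an aromatic carbon, meta to a methoxy group and para to a large group, gives a number 4.8 percentage points lower from compound 3 to compound 4 (within the scatter) in this assay and stays within the scatter. The same kind of change made at a different ring carbon gives a number 7.3 percentage points lower from compound 1 to compound 4 (within the scatter) and also stays within the scatter, so a second methoxy group on the ring shows no step beyond the scatter from either starting compound. No data are available that bear on the origin of these steps.

Still open, from the compounds shown here alone, is whether a hydroxy group or an amine at this aromatic carbon would give a step beyond the scatter. The same question stands for a longer chain on the oxygen of the added methoxy group.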